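From Methyl to Ethyl on Compound 2

This account rests on a few compounds, and the source may have more. Where it says the series, first, only, none or still open, it means among the compounds named here.

In a functional assay on HL-60 cells (Homo sapiens) for inhibition, read by MTT assay, with a stated time of 72 h (a higher number here means a weaker inhibitor, a lower number a stronger inhibitor), compound 2 `Cc1nc(-c2ccccc2Cl)c(C(=O)N2CCN(c3cccc(Cl)c3)CC2)o1` gives 132 nM as the higher of the two numbers measured. In the same test compound 1 `Cc1nc(-c2cccc(F)c2)c(C(=O)N2CCN(c3cccc(Cl)c3)CC2)o1` gives 33.7 nM as the lower number. Compound 3 `Cc1ccc(C)c(N2CCN(C(=O)c3oc(C)nc3-c3ccccc3Cl)CC2)c1` is reported only as a limit, > 1000 nM in this assay and no exact number. Putting 2-chlorophenyl in place of 3-fluorophenyl on an aromatic carbon gives a 3.9-fold higher number from compound 1 to compound 2 (0.59 log units; beyond the scatter) as a modest move. Putting 2,5-dimethylphenyl in place of 3-chlorophenyl on an amine nitrogen in a ring gives an at least 7.5-fold higher number from compound 2 to compound 3 (0.87 log units; beyond the scatter) in a step that rests on that limit.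

Compound 4 `CCc1nc(-c2ccccc2Cl)c(C(=O)N2CCN(c3cccc(Cl)c3)CC2)o1` changes a different place, with methyl in place of hydrogen on a saturated chain carbon bound to an aromatic carbon as the difference: methyl in place of hydrogen on a saturated chain carbon bound to an aromatic carbon, or methyl to ethyl. Neither measured step touches this place, so both bear on it only indirectly. They show that aryl exchanges can move the number in this assay beyond the scatter, while this change is a single methyl. The starting point is compound 2 at 132 nM in this series. The step expected is a 1.3-fold higher number from compound 2 to compound 4 (0.11 log units; within the scatter) by this estimate, with only a slight lean towards a higher number. Compound 4 is estimated at 170 nM with an expected range from 60 nM to 520 nM in that test.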

Compound 4, half-maximal inhibitory concentration: 98.9 nM
The estimate for compound 4 lay 1.7-fold (0.24 log units) above the measured number; low and high end bracket the measured number.
By their numbers in this assay, from the lowest: compound 1; then compounds 4 and 2 (each within the scatter of the next). At a limit, above all of these: compound 3.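

In this assay, methyl in place of hydrogen on a saturated chain carbon bound to an aromatic carbon, which reads as methyl to ethyl, gives a 1.3-fold lower number from compound 2 to compound 4 (0.13 log units; within the scatter), so this place, which neither earlier step touched, now has a measured step of its own. Going by these compounds alone, that step lies within the scatter, so compound 2 and compound 4 cannot be told apart in this test and the added methyl leaves the reading where it was, whereas both aryl exchanges among the earlier compounds moved the number beyond the scatter. Nothing measured here gives a reason for this outcome.

From the compounds shown here alone, what a longer chain such as propyl, or a chain ending in an amine or a carboxylic acid, would do at this place stays open. Going by these compounds, it also stays open whether methyl to ethyl would read the same way with 3-fluorophenyl on the aromatic carbon, as in compound 1, or with 2,5-dimethylphenyl on the amine nitrogen in a ring, as in compound 3.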